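The source may hold more compounds than are shown below. What is called first, only, known or untested is meant among the compounds shown, and "the series" means these compounds.

Three compounds were tested in a functional assay on KOPN-8 cells (Homo sapiens) for antiproliferative activity, with a stated time of 72 h; on this read-out lower numbers stand for an effect already at smaller amounts and higher numbers for an effect only at larger amounts of compound. Compound 1 `COC(=O)c1cc(=O)c2cc(N)ccc2[nH]1` gave only a limit, > 33700 nM, in this assay. Compound 2 `COc1ccc(-c2cc(=O)c3c(OC)cc(OC)cc3n2S(=O)(=O)c2ccc(C=O)cc2)cc1` likewise reached only a limit, > 34400 nM, as noted by the limit of > 34400 nM in this assay, at which 1 of the 3 values shown sits. Compound 3 `COc1ccc(-c2cc(=O)c3c(OC)cc(OC)cc3n2S(=O)(=O)c2c(C(C)C)cc(C(C)C)cc2C(C)C)cc1` also stopped at a limit, > 341000 nM, in this assay. Compound 2 thus stands among values that are all limits and no number. Compound 4 `COc1ccc(-c2cc(=O)c3c(OC)cc(OC)cc3n2S(=O)(=O)Cc2ccccc2)cc1` has not yet been measured in this assay and differs from compound 2 by benzyl in place of 4-formylphenyl on a sulfonyl sulfur. Since no change among the measured compounds is known, no step beyond the scatter is expected in this assay. Compound 4 is estimated at 40000 nM, between 10000 nM and 150000 nM, which is expected as a step that the limit leaves unreadable from compound 2 to compound 4.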

Compound 4, half-maximal effective concentration: > 34400 nM
Compound 4: no number, only a limit (the forecaster's own chance of this, stated with the estimate: 75%); the middle value does not contradict the limit.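

Compound 2 and compound 4 both stop at limits in this assay, so the step from 4-formylphenyl to benzyl on the sulfonyl sulfur cannot be read. The four compounds shown leave open what actual value any of them would have.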